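Fluorophenyl isomer at the aromatic nitrogen: compound 3

The source may report more compounds than this note shows. Statements on the series, on what has been measured and on what is new or still open speak of the compounds shown alone.

Measured so far:
compound 1 `Oc1cc(C(F)(F)F)ccc1-c1nc(-c2ccccc2O)n(-c2ccc(Br)cc2)n1`: 69.4%
compound 2 `Oc1cc(C(F)(F)F)ccc1-c1nc(-c2ccccc2O)n(-c2ccccc2F)n1`: 63.4%

In a functional assay on PC-12 cells (Rattus norvegicus) for cytotoxicity, read by MTT assay, with stated times of 2 h and 24 h, tested at 1 uM (a lower number here means a weaker effect, a higher number a stronger effect of the compound at the concentration tested), compound 1 gives 69.4%. Compound 2 gives 63.4% in this assay. The two numbers are within the scatter of each other, the step being a number 6 percentage points lower from compound 1 to compound 2 (within the scatter), so compound 2 cannot be set apart from compound 1 on this evidence; it simply has the nearer and only comparator.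

Compound 3 `Oc1cc(C(F)(F)F)ccc1-c1nc(-c2ccccc2O)n(-c2cccc(F)c2)n1` is not yet measured. It differs from compound 2 as follows: 3-fluorophenyl in place of 2-fluorophenyl on an aromatic nitrogen.

Going by the values given here, the only measured step that bears on this change is the one between compound 1 and compound 2, which also swaps the group on the same aromatic nitrogen, and there the read-out moved by a number 6 percentage points lower from compound 1 to compound 2 (within the scatter), within the scatter. A change from one fluorophenyl to another on that nitrogen is smaller than that swap. The expectation for compound 3 in this assay is therefore a step of a number 0.6 percentage points higher from compound 2 to compound 3 (within the scatter), that is, nothing beyond the scatter in either direction.

Compound 3 is estimated at 64%, with a range from 52% to 76%.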

Compound 3, a percentage reported as activity, at one concentration (the size of the read-out at that concentration, not a potency): 67.2%
Estimate against measurement, compound 3: 3.2 percentage points below, within the range that was stated.
By their numbers in this assay, from the lowest: compounds 2, 3 and 1 (each within the scatter of the next).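

Moving the fluorine on the phenyl group at this aromatic nitrogen, with the atom count unchanged, gives a pair of isomers, and in this assay the result is a number 3.8 percentage points higher from compound 2 to compound 3 (within the scatter) and no separation of the 2-fluorophenyl and 3-fluorophenyl compounds. The comparison with the heavier halogen group reads the same way, with a number 2.2 percentage points lower from compound 1 to compound 3 (within the scatter) on exchanging 4-bromophenyl for 3-fluorophenyl, so none of the three halophenyl groups at this position can be told apart in this read-out at the single concentration tested. No independent measurement accompanies these numbers to account for the flat result at this nitrogen.

The compounds shown leave open whether this read-out would stay flat with something other than a halogen on the phenyl group, such as an amine or a carboxylic acid, or with a longer alkyl chain on the nitrogen in place of the phenyl ring. They also leave open whether 4-fluorophenyl, which would complete the fluorine isomer set, would fall with these three, and whether any of the three would separate at other concentrations.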